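A few compounds are considered here, and "the series" means these few. Any claim that something is new, unique, unknown or untested is made for them only; others in the source may bear on it.

For the measured compounds named here, compound 2 `C=C1C(=O)O[C@H]2[C@H]1CC/C(COC(=O)Cn1cc(F)c(=O)n(Cc3ccc(F)cc3)c1=O)=C\CC[C@@]1(C)O[C@@H]21` is the one compound here with a number in a functional assay on Bel7402/5-FU cells (Homo sapiens) for antiproliferative activity, read by MTT assay, with a stated time of 72 h (a lower number here means a stronger inhibitor, a higher number a weaker inhibitor), where compound 2 gives 1140 nM. Compound 1 `C=C1C(=O)O[C@H]2[C@H]1CC/C(Cn1cc(Cn3cc(F)c(=O)[nH]c3=O)nn1)=C\CC[C@@]1(C)O[C@@H]21` is reported only as a limit of that assay: in this assay compound 1 gives > 20000 nM (the limit of > 20000 nM in this assay, at which 1 of the 2 values shown sits). So compound 2 stands alone as the measured reference point. Compound 3 `C=C1C(=O)O[C@H]2[C@H]1CC/C(COC(=O)Cn1cc(F)c(=O)n(C)c1=O)=C\CC[C@@]1(C)O[C@@H]21` differs from compound 2 by hydrogen in place of 4-fluorophenyl on a saturated chain carbon bound to an aromatic nitrogen. Going by the values given here, no measured step sets the size of such a change, so only a modest weakening is expected, a 2.2-fold higher number from compound 2 to compound 3 (0.34 log units; beyond the scatter). Compound 3 is estimated at 2500 nM in this assay, within 800 nM to 8000 nM.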

Compound 3, half-maximal inhibitory concentration: 11700 nM
For compound 3 the middle estimate is 4.7-fold (0.67 log units) below the measured one; measured number above the stated range.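

In this assay the change from 4-fluorobenzyl to methyl brings a 10-fold higher number from compound 2 to compound 3 (1.01 log units; beyond the scatter) and so gives the first measured sign that the group at this position strongly affects the result. The large 4-fluorobenzyl group goes with the lower number here, though one pair cannot set a trend. Nothing shown gives a measured reason for the size of this step. Still open, as far as these compounds go, is whether the fluorine, the aromatic ring or simply the length of the group matters. A plain benzyl or a straight butyl chain at this position would help separate these possibilities.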